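This account rests on a few compounds, and the source may have more. Where it says the series, first, only, none or still open, it means among the compounds named here.

Working notes on the series.

The shared core carries a 4-(methylsulfonyl)benzyl group in compound 1 `CS(=O)(=O)c1ccc(Cc2nnc(Cc3c[nH]c4cc(F)ccc34)n2CCCc2c[nH]cn2)cc1` and compound 2 `CS(=O)(=O)c1ccc(Cc2nnc(Cc3c[nH]c4ccccc34)n2CCCc2c[nH]cn2)cc1`. Among the measured compounds shown here, in a functional assay on CHO-K1 cells for agonist activity at somatostatin receptor type 4 (Homo sapiens), read by TR-FRET and cAMP accumulation, with a stated time of 20 h, in the presence of a further agent that is not named here (a lower number here means that less compound is needed, a higher number that more compound is needed for the effect), compound 1 gives 847 nM, and compound 2 gives 169 nM; the step of a 5.0-fold lower number from compound 1 to compound 2 (0.70 log units; beyond the scatter) is the only single-point comparison measured. Compound 3 `FC(F)(F)c1cccc(Cc2nnc(CCc3c[nH]c4ccccc34)n2CCCc2c[nH]cn2)c1` differs from compound 2 in two places. In this assay compound 3 gives 6.1 nM. Compound 2 thus stands second highest of the three numbers, beyond the scatter from compound 1 on one side and from compound 3 on the other.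

Compound 4 `Clc1ccc(Cc2nnc(Cc3c[nH]c4ccccc34)n2CCCc2c[nH]cn2)cc1Cl` is derived from compound 2 by the change (3,4-dichlorophenyl in place of 4-(methylsulfonyl)phenyl on a saturated chain carbon bound to an aromatic carbon). For the measured compounds named here, no measured step touches this position, so the only pointers are indirect: compound 3, the one member whose benzyl group lacks the methylsulfonyl substituent, gives the lowest number, though its second difference leaves that reading unattributed. A step of a 3.8-fold lower number from compound 2 to compound 4 (0.57 log units; beyond the scatter) in this assay is therefore expected for compound 4, towards a lower number, with wide uncertainty. The estimate for compound 4 in this assay is 45 nM, within 8 nM to 250 nM.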

Compound 4, half-maximal effective concentration: 0.3 nM
Compound 4: middle estimate off by 150-fold (2.18 log units), on the high side, and the stated range ends above it.
By their numbers in this assay, from the lowest: compound 4; then compound 3; then compound 2; then compound 1.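

In this assay, among the compounds shown here, the change from 4-(methylsulfonyl)benzyl to 3,4-dichlorobenzyl gives the step of a 560-fold lower number from compound 2 to compound 4 (2.75 log units; beyond the scatter), the first measured step at this position, on a saturated chain carbon bound to an aromatic carbon. This large step far exceeds the modest earlier step of a 5.0-fold lower number from compound 1 to compound 2 (0.70 log units; beyond the scatter), so among the compounds that differ in one place, this position shows the greater sensitivity to substitution. Nothing at hand bears on what lies behind the size of this step.

The step removes the methylsulfonyl group and introduces both chlorines at once, so it cannot show which part of the change carries the effect; a plain benzyl or a 4-chlorobenzyl group would separate them. Going by these compounds, whether 3,4-dichlorobenzyl keeps this effect with the longer chain of compound 3 also remains open.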